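A few compounds are considered here, and "the series" means these few. Any claim that something is new, unique, unknown or untested is made for them only; others in the source may bear on it.

Compound 1 `O=C(CN1CCN(c2nnc(Cc3ccncc3)c3ccccc23)CC1)Nc1cccc(F)c1`: 4600 nM
Compound 2 `O=C(CN1CCN(c2nnc(Cc3ccccc3)c3ccccc23)CC1)Nc1cc(C(F)(F)F)ccc1Cl`: 89000 nM
Compound 3 `O=C(CN1CCN(c2nnc(Cc3ccccc3)c3ccccc23)CC1)Nc1cccc(F)c1`: 130000 nM

In a functional assay on A549 cells (Homo sapiens) for cytotoxicity, read by MTT assay, with a stated time of 72 h (on this read-out lower numbers stand for stronger inhibition and higher numbers for weaker inhibition), compound 1 gives the lowest number of the three, with compound 2 and compound 3 standing well higher, as a 28-fold higher number from compound 1 to compound 3 (1.45 log units; beyond the scatter) shows. Compound 4 `Cc1cccc(Cl)c1NC(=O)CN1CCN(c2nnc(Cc3ccncc3)c3ccccc23)CC1` differs from compound 1 only at the amide-type nitrogen: 2-chloro-6-methylphenyl in place of 3-fluorophenyl on an amide-type nitrogen. For the measured compounds named here, the one measured step at that same place, a 1.5-fold higher number from compound 2 to compound 3 (0.16 log units; within the scatter), stayed within the scatter, so swapping the group on the amide-type nitrogen is expected to leave the number close to that of compound 1. The large step, a 28-fold higher number from compound 1 to compound 3 (1.45 log units; beyond the scatter), concerned a different place, and compound 4 keeps the pyridin-4-yl of compound 1. Compound 4 is therefore estimated at 5000 nM, with a range from 1500 nM to 16000 nM, a step of a 1.1-fold higher number from compound 1 to compound 4 (0.04 log units; within the scatter) that is expected to remain within the scatter.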

Compound 4, half-maximal inhibitory concentration: 7190 nM
The estimate for compound 4 lay 1.4-fold (0.16 log units) below the measured number; the measured number falls inside the stated range.
By their numbers in this assay, from the lowest: compounds 1 and 4 (each within the scatter of the next); then compounds 2 and 3 (each within the scatter of the next).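

In this assay the exchange gives a 1.6-fold higher number from compound 1 to compound 4 (0.19 log units; within the scatter) and shows that the group on the amide-type nitrogen can change with no shift beyond the scatter while pyridin-4-yl is kept. The earlier step at this place came only from compounds carrying phenyl instead of pyridin-4-yl. No measured evidence here explains this result. Still open, going by these compounds, is whether the number would hold with something other than a substituted phenyl on that nitrogen, such as a cyclohexyl group or a longer chain ending in an amine.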